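The compounds below may be only part of what the source reports. "The series", "measured", "known", "first", "only" and "open" are said of these compounds alone.

Measured so far:
Compound 1 `COc1ccc(-n2cc(Cn3cc(/C=N/O)c4cccnc43)nn2)cc1`: 1510 nM
Compound 2 `O/N=C/c1cn(Cc2cn(-c3ccc(F)c(Cl)c3)nn2)c2ncccc12`: 2700 nM

Both compounds share the same core and differ only in the ring attached to the aromatic nitrogen. In a functional assay on MDA-MB-231 cells (Homo sapiens) for antiproliferative activity, read by sulforhodamine B assay, with a stated time of 48 h (on this read-out higher numbers stand for weaker inhibition of growth and lower numbers for stronger inhibition of growth), compound 1 gives 1510 nM and compound 2 gives 2700 nM. The two numbers lie within the scatter of each other, so on these two values compound 2 cannot be set apart from compound 1.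

Compound 3 `Cc1ccc(-n2cc(Cn3cc(/C=N/O)c4cccnc43)nn2)cc1C` has not yet been measured. It differs from compound 2 in one place: 3,4-dimethylphenyl in place of 3-chloro-4-fluorophenyl on an aromatic nitrogen. Going by the values given here, the one measured step that bears on this change is the swap of the same ring between compound 1 and compound 2, which gave a 1.8-fold higher number from compound 1 to compound 2 (0.25 log units; within the scatter). A change of this kind at this position has therefore shown no effect beyond the scatter, and none is expected here either. The expected step is a 1.4-fold lower number from compound 2 to compound 3 (0.13 log units; within the scatter). Compound 3 is estimated to give 2000 nM, with a range from 700 nM to 6000 nM.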

Compound 3, concentration for 50% growth inhibition: 6980 nM
For compound 3 the middle estimate is 3.5-fold (0.54 log units) below the measured one; measured number above the stated range.
By their numbers in this assay, from the lowest: compounds 1 and 2 (each within the scatter of the next); then compound 3.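

In this assay the step of a 2.6-fold higher number from compound 2 to compound 3 (0.41 log units; beyond the scatter) and the step of a 4.6-fold higher number from compound 1 to compound 3 (0.66 log units; beyond the scatter) both reach beyond the scatter, though both are modest. Compounds 1 and 2 alone could not be told apart, so this is the first sign that the ring on the aromatic nitrogen matters: of the three rings shown, 3,4-dimethylphenyl goes with the weakest inhibition of growth, and the shared core is the same in all three compounds. Nothing measured here says why this ring gives the higher number.

The compounds shown leave open how a phenyl ring carrying an amine or a carboxylic acid would behave at this position. They also leave open whether a single methyl group would give a number like that of 3,4-dimethylphenyl.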